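The compounds below may be only part of what the source reports. "The series", "measured", "known", "first", "only" and "open" are said of these compounds alone.

Two members of this series have been examined in a physicochemical assay for acid dissociation. Compound 1 `COc1ccc(Oc2ccc3c(NCCCNCc4cccc(OC)c4O)ccnc3c2)cc1` gives 9.28 in this assay, and compound 2 `Fc1ccc(Cc2ccc3c(NCCCNCc4ccco4)ccnc3c2)c(Cl)c1` gives 9.47, the two numbers lying within the scatter of each other, so no order can be read between them. Compound 3 `COc1ccc(Oc2ccc3c(NCCCNCc4ccco4)ccnc3c2)cc1` differs from compound 2 only by 4-methoxyphenoxy in place of 2-chloro-4-fluorobenzyl on an aromatic carbon, a change far from the chain bearing the secondary amine. No change beyond the scatter is expected from compound 2 to compound 3 in this assay, the estimated step being a number 0.07 log units lower from compound 2 to compound 3 (within the scatter). Compound 3 is therefore expected to give about 9.4, within 9.05 to 9.75.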

Compound 3, acid dissociation constant: 9.28
Compound 3: middle estimate off by 0.12 log units, on the high side, within the range that was stated.
By their numbers in this assay, from the lowest: compounds 1, 3 and 2 (each within the scatter of the next).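

In this assay, 4-methoxyphenoxy in place of 2-chloro-4-fluorobenzyl on this aromatic carbon gives a number 0.19 log units lower from compound 2 to compound 3 (within the scatter) and so leaves the read-out unmoved beyond the scatter. Furan-2-yl in place of 2-hydroxy-3-methoxyphenyl on the saturated chain carbon bound to an amine nitrogen gives no change at the digits printed from compound 1 to compound 3 (within the scatter) and likewise stays within the scatter. No measurement at hand gives a reason for either result. Still open, from the compounds shown here alone, is whether an amine or a carboxylic acid on this aromatic carbon, or a longer chain bearing the secondary amine, would shift the value beyond the scatter.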